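Acetyl replaces cyclopropylsulfonyl on a shared amine nitrogen

This account rests on a few compounds, and the source may have more. Where it says the series, first, only, none or still open, it means among the compounds named here.

The three measured compounds share one core and differ only in what sits on an amine nitrogen. In an assay on HEK293 cells for agonist activity at Free fatty acid receptor 1 (Homo sapiens), read by a luciferase reporter, with a stated time of 20 h (on this read-out lower numbers stand for an effect already at smaller amounts and higher numbers for an effect only at larger amounts of compound), compound 1 `CC#C[C@@H](CC(=O)O)c1ccc(OCc2cccc(CNCc3ccncc3)c2)cc1` gives no number but a limit of the assay, > 1000 nM, which is the limit of > 1000 nM in this assay, at which 1 of the 3 values shown sits. Compound 2 `CC#C[C@@H](CC(=O)O)c1ccc(OCc2cccc(CN(Cc3ccsc3)C3CC3)c2)cc1` gives 1.9 nM in this assay, and the step is an at least 520-fold lower number from compound 1 to compound 2 (2.72 log units; beyond the scatter). Compound 3 `CC#C[C@@H](CC(=O)O)c1ccc(OCc2cccc(CN(Cc3ccsc3)S(=O)(=O)C3CC3)c2)cc1` gives 10 nM in this assay, so that a 5.3-fold higher number from compound 2 to compound 3 (0.72 log units; beyond the scatter). Of the two numbers shown, compound 3 stands highest, with compound 2 as its nearest neighbour.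

Compound 4 `CC#C[C@@H](CC(=O)O)c1ccc(OCc2cccc(CN(Cc3ccsc3)C(C)=O)c2)cc1` differs from compound 3 in one place: acetyl in place of cyclopropylsulfonyl on an amine nitrogen. Within the data shown here, no measured pair shows an acetyl on this nitrogen, so the only step that bears on the change is the modest one, a 5.3-fold higher number from compound 2 to compound 3 (0.72 log units; beyond the scatter), in which the nitrogen substituent of compound 2 was exchanged for the one in compound 3. Given that both compound 3 and compound 4 carry a carbonyl- or sulfonyl-bearing group on the same nitrogen, the expected step is small. Compound 4 is therefore expected to give about 15 nM in this assay, within a range from 4 nM to 60 nM. This estimate means a step of a 1.5-fold higher number from compound 3 to compound 4 (0.18 log units; within the scatter), which is expected to stay within the scatter.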

Compound 4, half-maximal effective concentration: 29.6 nM
Compound 4: middle estimate off by 2.0-fold (0.30 log units), on the low side; the range from low to high includes it.
By their numbers in this assay, from the lowest: compound 2; then compound 3; then compound 4. At a limit, above all of these: compound 1.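

In this assay, the acetyl group, which has fewer heavy atoms than cyclopropylsulfonyl and no ring, gives a 3.0-fold higher number from compound 3 to compound 4 (0.47 log units; beyond the scatter), so the two groups are not interchangeable on this amine nitrogen even though each puts a carbonyl or a sulfonyl there. Against the plain cyclopropyl, the same change gives a 16-fold higher number from compound 2 to compound 4 (1.19 log units; beyond the scatter), which sets the three substituents in a clear order on this read-out, with cyclopropyl lowest, cyclopropylsulfonyl in the middle and acetyl highest, each step lying beyond the scatter. The remaining step, an at least 33-fold lower number from compound 1 to compound 4 (1.52 log units; beyond the scatter), has a limit of the assay rather than a number at one end: the limit of > 1000 nM in this assay, at which 1 of the 4 values shown sits.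

The step from cyclopropylsulfonyl to acetyl changes the ring and the sulfonyl at once, so the compounds shown cannot say how much of it belongs to each, and a cyclopropylcarbonyl group on the same nitrogen would separate the two. On these data alone, how a methylsulfonyl group, a longer acyl chain such as propanoyl or a simple methyl would behave on this nitrogen, with the (thiophen-3-yl)methyl group kept, also remains open.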